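The source may report more compounds than this note shows. Statements on the series, on what has been measured and on what is new or still open speak of the compounds shown alone.

Compound 1 `COc1cccc(C2CCc3nc[nH]c3C2)c1` is an aryl-substituted bicyclic imidazole bearing a methoxy group. In a functional assay on CHO cells for agonist activity at Alpha-1D adrenergic receptor (Homo sapiens), read by FLIPR and calcium flux (on this read-out lower numbers stand for an effect already at smaller amounts and higher numbers for an effect only at larger amounts of compound), compound 1 gives only a limit, > 10000 nM, and no number. Its close relative compound 2 `c1ccc(C2CCc3nc[nH]c3C2)cc1` in this assay likewise reaches only the limit, > 10000 nM; > 10000 nM; > 10000 nM (3 entries), in each of its entries. Compound 1 therefore stands at the limit of > 10000 nM in this assay, at which 1 of the 2 values shown sits. Compound 3 `Clc1cccc(C2CCc3nc[nH]c3C2)c1` differs from compound 1 by chloro in place of methoxy on an aromatic carbon. Among the measured compounds shown here, since no step between measured compounds is available, no direction of change can be drawn; the step from compound 1 to compound 3 is expected to stay within the scatter, at a step that the limit leaves unreadable from compound 1 to compound 3. Compound 3 is estimated at 15000 nM, between 4000 nM and 60000 nM.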

Compound 3, half-maximal effective concentration: > 10000 nM
Compound 3 gave a limit, no number; the forecaster's own chance of this, stated with the estimate: 80%; the middle value lies beyond the limit too.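

Compound 1 and compound 3 both give only a limit, so no step can be read between them: the limit of > 10000 nM in this assay, at which 2 of the 3 values shown sit. The compounds shown leave open whether a substituent on this aromatic ring can bring a measurable value in this assay.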